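Extending the side chain on the shared core of compound 2

The source may hold more compounds than are shown below. What is called first, only, known or untested is meant among the compounds shown, and "the series" means these compounds.

Measured compounds:
compound 1 `COCc1cc(COc2ccc([C@]3(N)CCN([C@H](CC(C)C)C(=O)NO)C3=O)cc2)c2ccccc2n1`, 1210 nM
compound 2 `Cc1cc(COc2ccc([C@]3(N)CCN([C@H](CC(C)C)C(=O)NO)C3=O)cc2)c2ccccc2n1`, 480 nM

In an assay on isolated protein for inhibition of disintegrin and metalloproteinase domain-containing protein 10 (Homo sapiens), read by FRET (on this read-out lower numbers stand for stronger inhibition and higher numbers for weaker inhibition), compound 2 gives 480 nM, the lowest of the two numbers; compound 1 gives 1210 nM. Compound 3 `COCCc1cc(COc2ccc([C@]3(N)CCN([C@H](CC(C)C)C(=O)NO)C3=O)cc2)c2ccccc2n1` carries methoxymethyl in place of hydrogen on a saturated chain carbon bound to an aromatic carbon. For the measured compounds named here, the only step that bears on it is a 2.5-fold lower number from compound 1 to compound 2 (0.40 log units; beyond the scatter), where removing a methoxy on the same chain carbon lowered the number. Compound 3 places an oxygen on that chain again, one bond further out, so a modest rise is expected, a 1.9-fold higher number from compound 2 to compound 3 (0.27 log units; within the scatter). Compound 3 is estimated at 900 nM, between 400 nM and 2000 nM.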

Compound 3, half-maximal inhibitory concentration: 1200 nM
Compound 3: middle estimate off by 1.3-fold (0.12 log units), on the low side; the range from low to high includes it.
By their numbers in this assay, from the lowest: compound 2; then compounds 3 and 1 (each within the scatter of the next).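

In this assay, methoxymethyl at this saturated chain carbon bound to an aromatic carbon gives a 2.5-fold higher number from compound 2 to compound 3 (0.40 log units; beyond the scatter), so moving the oxygen one bond further out does not recover the lower number of the methyl-bearing compound 2. Exchanging methoxy for methoxymethyl gives a 1.0-fold lower number from compound 1 to compound 3 (0.00 log units; within the scatter), which leaves the two chains indistinguishable here. No evidence at hand explains this result. As far as these compounds go, what an ethyl chain or an amine at this place would give stays open, and with it whether the higher numbers follow the oxygen or the chain length.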